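Aryl-chain variation in K562 antiproliferation series

The source may hold more compounds than are shown below. What is called first, only, known or untested is meant among the compounds shown, and "the series" means these compounds.

Measured compounds:
compound 1 `COc1ccc(/C=C/C(=O)c2ccc(OC)c3c2OC(C)(C)C=C3)cn1` — > 10000 nM
compound 2 `COc1ccc(C(=O)/C=C/c2ccsc2)c2c1C=CC(C)(C)O2` — > 10000 nM

In a functional assay on K562 cells (Homo sapiens) for antiproliferative activity, read by MTT assay, with a stated time of 24 h (on this read-out higher numbers stand for weaker inhibition and lower numbers for stronger inhibition), compound 1 gives > 10000 nM, which is a limit of the assay and not a number. In this assay compound 2 gives > 10000 nM, also a limit. Within the data shown here, the only step among measured compounds, a step that the two limits leave unreadable from compound 1 to compound 2, is accordingly unreadable, because of the limit of > 10000 nM in this assay, at which 2 of the 2 values shown sit. Compound 2 therefore stands only at a limit of this assay; no number fixes its position.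

Compound 3 `COc1ccc(C(=O)/C=C/c2ccc(Cl)c(Cl)c2)c2c1C=CC(C)(C)O2` differs from compound 2 by 3,4-dichlorophenyl in place of thiophen-3-yl on a double-bonded chain carbon bound to a double-bonded chain carbon. Among the measured compounds shown here, no measured step bears on this change: the single step on record concerns a different pair of groups and its own size cannot be read. The data thus give neither direction nor size for the change from compound 2 to compound 3, and the nearest point of comparison, compound 2, returned only a limit.

Compound 3 is expected to give 15000 nM in this assay, with a range from 3000 nM to 60000 nM, and most probably to be reported as a limit again. The step that the limit leaves unreadable from compound 2 to compound 3 that this estimate means is set at about nil, as an expectation only.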

Compound 3, half-maximal inhibitory concentration: 9030 nM
Compound 3: the middle estimate sits 1.7-fold (0.22 log units) above what was measured; the range from low to high includes it.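

Among these compounds, on the double-bonded chain carbon bound to a double-bonded chain carbon, 3,4-dichlorophenyl gives the one true number so far in this assay: compound 3 reads 9030 nM, so this place can now yield a measurable value. Set against thiophen-3-yl the change reads as an at least 1.1-fold lower number from compound 2 to compound 3 (0.04 log units; that floor lies within the scatter), and set against 6-methoxypyridin-3-yl it reads as an at least 1.1-fold lower number from compound 1 to compound 3 (0.04 log units; that floor lies within the scatter). Both figures are floors and their true sizes stay unfixed, because compound 1 and compound 2 each stand at a limit and not at a number: the limit of > 10000 nM in this assay, at which 2 of the 3 values shown sit.

The compounds shown do not tell whether both chlorines are needed for a reading in range, or what a single chlorine as in 4-chlorophenyl, or an amine as in 4-aminophenyl, would give at this place. Going by these compounds, it also remains open how thiophen-3-yl and 6-methoxypyridin-3-yl rank against each other, since the step between them cannot be read, and whether any group at this place brings the number clearly beyond the scatter of the limit.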